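The compounds below may be only part of what the source reports. "The series", "measured", "known", "first", "only" and "open" are said of these compounds alone.

Three compounds have been measured in a functional assay on the whole organism (Tail, strain ICR) with Mus musculus as the target, in the tail flick test, with a stated time of 30 min, at a dose of 25 umol/kg by the oral route; on this read-out lower numbers stand for a weaker effect and higher numbers for a stronger effect at the one dose given:

Compound 1, `CSCC[C@H](NC(=O)CN(c1nc(Cl)nc2[nH]cnc12)C1CC1)C(=O)OCc1ccccc1`, gives 22.2%.
Compound 2, `CC(C)C[C@H](NC(=O)CN(c1nc(Cl)nc2[nH]cnc12)C1CC1)C(=O)OCc1ccccc1`, gives 33.9%.
Compound 3, `CC(C)C[C@H](NC(=O)CN(c1ncnc2c1ncn2C1CCCCO1)C1CC1)C(=O)OCc1ccccc1`, gives 26.2%.

Compound 1 and compound 2 share one core and differ in a single place: (methylsulfanyl)methyl in place of isopropyl on a saturated chain carbon, two bonds along the chain from an amide-type nitrogen and a carbonyl carbon. This change made a step of a number 11.7 percentage points lower from compound 2 to compound 1 (beyond the scatter), so the compound carrying the (methylsulfanyl)methyl group came out weaker than its isopropyl partner on this read-out.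

Compound 3 carries a different core from compound 2; the difference between the two cores is not broken down here. Its value sits within the usual scatter of both compound 1 and compound 2, so no order among the three can be read from it.

Compound 4, `CSCC[C@H](NC(=O)CN(c1ncnc2c1ncn2C1CCCCO1)C1CC1)C(=O)OCc1ccccc1`, has not yet been measured. It is related to compound 3 in the same way that compound 1 is related to compound 2: (methylsulfanyl)methyl in place of isopropyl on a saturated chain carbon, two bonds along the chain from an amide-type nitrogen and a carbonyl carbon. The place of the change is described in the same words for both pairs, so this is the same change on a different core.

Within the data shown here, on the one earlier example, the change lowered the read-out by a modest amount. If compound 4 follows that example, a step of about a number 11.2 percentage points lower from compound 3 to compound 4 (beyond the scatter) is expected, resting on the single step from compound 2 to compound 1 and the value of compound 3, 26.2%. Among the measured compounds shown here, compound 4 is therefore expected to give roughly 15% in this assay, with a plausible range from 5% to 28%, the width reflecting that only one prior instance of the change is available and that it sits on another core.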

Compound 4, a percentage reported as activity, at one dose (the size of the read-out at that dose, not a potency): 30%
For compound 4 the middle estimate is 15 percentage points below the measured one; measured number above the stated range.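

Among these compounds, on the core of compound 3, putting (methylsulfanyl)methyl in place of isopropyl gave a number 3.8 percentage points higher from compound 3 to compound 4 (within the scatter) in this assay, so on this core the change produced no step that stands out from the usual variation between repeated measurements. Set beside the earlier pair, the same change did not carry over from one core to the other: the same change on two cores in this assay, a number 11.7 percentage points lower (beyond the scatter) from compound 2 to compound 1 and a number 3.8 percentage points higher (within the scatter) from compound 3 to compound 4, 15.5 percentage points apart, beyond the scatter of two such steps This shows that, for these two pairs, the step seen on one core was a poor guide to the step on the other, but it does not show why the two differ, which part of the cores matters, or what the change would do on any further core.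

The compounds shown leave open whether a longer chain, an amine or a carboxylic acid at this saturated chain carbon would give matching or differing steps on the two cores, since only isopropyl and (methylsulfanyl)methyl appear there. They also leave open whether the difference between the two steps would persist at other doses or other times, since each compound is represented by one reading at one dose and one stated time.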